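Diethylamino to dimethylamino on the benzyl chain of compound 3

This account rests on a few compounds, and the source may have more. Where it says the series, first, only, none or still open, it means among the compounds named here.

Measured so far in a functional assay on MDA-MB-231 cells (Homo sapiens) for cytotoxicity, read by MTT assay, with a stated time of 72 h; on this read-out higher numbers stand for weaker inhibition and lower numbers for stronger inhibition:
compound 1 `CN(C)Cc1ccc2nc(NC(=O)N/N=C/c3cn(Cc4ccccc4)c4ccccc34)sc2c1` gives 1340 nM
compound 2 `CN(C)Cc1ccc2nc(NC(=O)N/N=C/c3cn(Cc4ccc(Cl)cc4)c4ccccc34)sc2c1` gives 880 nM
compound 3 `CCN(CC)Cc1ccc2nc(NC(=O)N/N=C/c3cn(Cc4ccc(Cl)c(Cl)c4)c4ccccc34)sc2c1` gives 4490 nM

Compound 3 stands highest of the three numbers; its nearest neighbour is compound 1 and its furthest is compound 2, both gaps beyond the scatter. Compound 4 `CN(C)Cc1ccc2nc(NC(=O)N/N=C/c3cn(Cc4ccc(Cl)c(Cl)c4)c4ccccc34)sc2c1` is not yet measured. The change from compound 3 to compound 4 is dimethylamino in place of diethylamino on a saturated chain carbon bound to an aromatic carbon. For the measured compounds named here, the one measured step, a 1.5-fold lower number from compound 1 to compound 2 (0.18 log units; within the scatter), concerns the chloro on the benzyl ring and not the amine, so no measured step bears directly on the change here. Going by the values given here, what the numbers show is only that compound 1 and compound 2, which both carry the dimethylamino group, give lower numbers than compound 3, but compound 3 also differs from them in the dichloro pattern, so the two changes cannot be separated. The estimate for compound 4 is therefore a move toward the numbers of compound 1 and compound 2, expected as a 2.8-fold lower number from compound 3 to compound 4 (0.45 log units; beyond the scatter), with wide uncertainty. Compound 4 is expected to give about 1600 nM, within a range from 600 nM to 4500 nM in this assay.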

Compound 4, half-maximal inhibitory concentration: 1000 nM
Compound 4: middle estimate off by 1.6-fold (0.20 log units), on the high side; the measured number falls inside the stated range.
By their numbers in this assay, from the lowest: compounds 2, 4 and 1 (each within the scatter of the next); then compound 3.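

In this assay, for the compounds shown here, dimethylamino in place of diethylamino on a saturated chain carbon bound to an aromatic carbon gives a 4.5-fold lower number from compound 3 to compound 4 (0.65 log units; beyond the scatter) and this is the first measured step at this position, lying beyond the scatter. With dimethylamino kept in place, the benzyl ring changes give a 1.1-fold higher number from compound 2 to compound 4 (0.06 log units; within the scatter) for chloro in place of hydrogen and a 1.3-fold lower number from compound 1 to compound 4 (0.13 log units; within the scatter) for 3,4-dichlorophenyl in place of phenyl and both lie within the scatter, so the dichloro pattern alone moves the number by no more than the scatter in this setting. Among the single-place changes shown, the amine change is thus the only one that lies beyond the scatter, which separates the two differences that compound 3 carried against compound 1 and compound 2.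

The compounds shown leave open whether the amine step holds with phenyl or 4-chlorophenyl on the benzyl position, and how a dipropylamino group or a primary amine at the same place would read. No measured evidence is available to explain the step from diethylamino to dimethylamino.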